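Benzyl for methylsulfonyl on the amine of compound 3

A few compounds are considered here, and "the series" means these few. Any claim that something is new, unique, unknown or untested is made for them only; others in the source may bear on it.

Three compounds have numbers in an assay on isolated protein for inhibition of microsomal triglyceride transfer protein large subunit (Homo sapiens); a higher number here means a weaker inhibitor, a lower number a stronger inhibitor. Compound 1 `COC(=O)N[C@H]1Cc2ccc(NC(=O)c3cc(C(F)(F)F)ccc3-c3ccc(C(F)(F)F)cc3)cc2C1` gives 410 nM in this assay. Compound 2 `Cc1cccc(C(=O)Nc2ccc3c(c2)CC(NS(=O)(=O)c2ccccc2)C3)c1-c1ccc(C#N)cc1` gives 120 nM in this assay. Compound 3 `CS(=O)(=O)NC1Cc2ccc(NC(=O)c3ccccc3-c3ccc(C(F)(F)F)cc3)cc2C1` gives 120 nM in this assay, level with compound 2 at the digits shown and within the scatter of it; together they hold the lowest two numbers of the three, and compound 1 stands above compound 3 by a gap that lies beyond the scatter. For the measured compounds named here, no pair among the measured compounds differs in one place only, so no single step can be read off from them.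

Compound 4 `O=C(Nc1ccc2c(c1)CC(NCc1ccccc1)C2)c1ccccc1-c1ccc(C(F)(F)F)cc1` is next for this assay. It differs from compound 3 in one place: benzyl in place of methylsulfonyl on an amine nitrogen. All three measured compounds carry a carbonyl or sulfonyl group on that nitrogen; compound 4 carries none, so the measured set gives no direct guide to this change. The expectation is a small step, if any, from compound 3 to compound 4, with the wide uncertainty that the lack of a precedent brings: a 1.7-fold higher number from compound 3 to compound 4 (0.22 log units; within the scatter). Compound 4 is estimated at 200 nM in this assay, within a range of 50 nM to 800 nM.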

Compound 4, half-maximal inhibitory concentration: 4800 nM
The estimate for compound 4 lay 24-fold (1.38 log units) below the measured number, outside the stated range (above it).
By their numbers in this assay, from the lowest: compounds 2 and 3 (each within the scatter of the next); then compound 1; then compound 4.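

Benzyl in place of methylsulfonyl on the amine nitrogen gives a 40-fold higher number from compound 3 to compound 4 (1.60 log units; beyond the scatter) in this assay and so shows that this position does not tolerate every group. Compound 4 is the only one of the four with neither a carbonyl nor a sulfonyl group on that nitrogen, which makes this the first read on such a nitrogen in the series, though from a single pair. The pair cannot separate the loss of methylsulfonyl from the arrival of benzyl, and nothing available here explains the size of the step.

Still open, as far as these compounds go, is which of those two changes matters more. The free amine, an acetyl group and a benzoyl group on that nitrogen would help to separate them.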